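The source may report more compounds than this note shows. Statements on the series, on what has been measured and on what is new or still open speak of the compounds shown alone.

Measured in a functional assay on DU-145 cells (Homo sapiens) for cytotoxicity, read by MTT assay; a higher number here means a weaker inhibitor, a lower number a stronger inhibitor:
Compound 1 `CCCC(CC(=O)O[C@H](CC=C(C)C)C1=CC(=O)c2c(O)ccc(O)c2C1=O)OC(C)=O`: 55700 nM
Compound 2 `CC(C)=CC[C@@H](OCC(C)O)C1=CC(=O)c2c(O)ccc(O)c2C1=O`: 16100 nM
Compound 3 `CC(C)=CC[C@@H](OC(=O)CC(O)c1ccccc1)C1=CC(=O)c2c(O)ccc(O)c2C1=O`: 17000 nM

Compound 3 cannot be told apart from compound 2 on these numbers, and both carry a clearly lower number than compound 1. The next compound to be read is compound 4 `CCCC(C)(O)CC(=O)O[C@H](CC=C(C)C)C1=CC(=O)c2c(O)ccc(O)c2C1=O`, which keeps the shared core and changes one group: 1-hydroxy-1-methylbutyl in place of hydroxy(phenyl)methyl on a saturated chain carbon bound to a carbonyl carbon. The incoming group has no ring, and neither has the 1-acetoxybutyl of compound 1.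

Among the measured compounds shown here, only one measured step bears on this change: a 3.3-fold lower number from compound 1 to compound 3 (0.52 log units; beyond the scatter). That step installed the hydroxy(phenyl)methyl group that compound 4 now gives up, so a move towards a higher number is the likely direction. The incoming group keeps a free hydroxy, whereas 1-acetoxybutyl has none, so only part of that modest step is expected to return, and the change may stay within the scatter. The expected change is a 1.5-fold higher number from compound 3 to compound 4 (0.17 log units; within the scatter). For compound 4 the estimated value is 25000 nM, with an expected range of 12000 nM to 55000 nM.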

Compound 4, half-maximal inhibitory concentration: 75000 nM
For compound 4 the middle estimate is 3.0-fold (0.48 log units) below the measured one; measured number outside the range, above it.
By their numbers in this assay, from the lowest: compounds 2 and 3 (each within the scatter of the next); then compounds 1 and 4 (each within the scatter of the next).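

In this assay, a free hydroxy on the incoming group does not hold the number down: 1-hydroxy-1-methylbutyl and hydroxy(phenyl)methyl each carry one, yet the exchange gives a clear rise (a 4.4-fold higher number from compound 3 to compound 4 (0.64 log units; beyond the scatter)), while the step to the hydroxy-free 1-acetoxybutyl compound stays within the scatter (a 1.3-fold higher number from compound 1 to compound 4 (0.13 log units; within the scatter)). Losing the ring could fit this rise, but compound 2 goes against ring presence as a sufficient account: its ringless 2-hydroxypropyl ether also lies clearly lower (a 4.7-fold higher number from compound 2 to compound 4 (0.67 log units; beyond the scatter)). No measured data here explain these differences.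

These compounds do not separate the loss of the phenyl ring from the added methyl and longer chain in 1-hydroxy-1-methylbutyl. A 1-hydroxybutyl group, or hydroxy(cyclohexyl)methyl at the same place, would bear on that question.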